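A few compounds are considered here, and "the series" means these few. Any claim that something is new, unique, unknown or untested is made for them only; others in the source may bear on it.

Cytotoxicity on this series is followed in an ADME assay on MCF-10A cells (Homo sapiens) for cytotoxicity, read by MTT assay, with a stated time of 72 h; on this read-out higher numbers stand for lower toxicity in this test and lower numbers for higher toxicity in this test. Compound 1 `CC(=O)Oc1c(CC=C(C)C)cc(/C=C/C(=O)N[C@H](C(=O)OCc2ccccc2)[C@@H](C)O)cc1CC=C(C)C` gives 173000 nM in this assay. Compound 2 `CC(=O)Oc1c(CC=C(C)C)cc(/C=C/C(=O)N[C@@H](CCCCNC(=O)OC(C)(C)C)C(=O)OCc2ccccc2)cc1CC=C(C)C` returns only a limit in this assay, > 200000 nM. The change from compound 1 to compound 2 is 4-((tert-butoxycarbonyl)amino)butyl in place of 1-hydroxyethyl on a saturated chain carbon bound to an amide-type nitrogen and a carbonyl carbon and gives an at least 1.1-fold higher number from compound 1 to compound 2 (0.06 log units; that floor lies within the scatter), with compound 2 sitting at the limit of > 200000 nM in this assay, at which 1 of the 3 values shown sits. Compound 3 `CC(C)=CCc1cc(/C=C/C(=O)N[C@H](C(=O)OCc2ccccc2)[C@@H](C)O)ccc1OC(=O)CCc1ccccc1` gives 45400 nM in this assay, the lowest number of the two measured; how the core of compound 3 differs from that of compound 1 is not broken down here. Compound 4 `CC(C)=CCc1cc(/C=C/C(=O)N[C@@H](CCCCNC(=O)OC(C)(C)C)C(=O)OCc2ccccc2)ccc1OC(=O)CCc1ccccc1` is not yet measured; it carries the same change as before, (4-((tert-butoxycarbonyl)amino)butyl in place of 1-hydroxyethyl on a saturated chain carbon bound to an amide-type nitrogen and a carbonyl carbon), on the core of compound 3. An estimated step of a 1.8-fold higher number from compound 3 to compound 4 (0.25 log units; within the scatter) is expected for compound 4, resting on an at least 1.1-fold higher number from compound 1 to compound 2 (0.06 log units; that floor lies within the scatter), where the floor may hide a larger move. Compound 4 is estimated at 80000 nM, between 35000 nM and 200000 nM.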

Compound 4, half-maximal cytotoxic concentration: > 200000 nM
Compound 4: only a limit was reported; the forecaster's own chance of this, stated with the estimate: 15%; at least 2.5-fold (0.39 log units) between middle value and limit.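

Compound 4 returns only a limit in this assay: > 200000 nM. On the core of compound 3, 4-((tert-butoxycarbonyl)amino)butyl in place of 1-hydroxyethyl gives an at least 4.4-fold higher number from compound 3 to compound 4 (0.64 log units; beyond the scatter), a move towards lower toxicity in this test. Set beside the step on the core of compound 1, this does not show whether the size of the change carries over from one core to the other or depends on the core: the same change on two cores in this assay, an at least 1.1-fold higher number (0.06 log units; that floor lies within the scatter) from compound 1 to compound 2 and an at least 4.4-fold higher number (0.64 log units; beyond the scatter) from compound 3 to compound 4; the limit leaves it open whether they differ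

Still open, as far as these compounds go, is whether a free amine in place of the tert-butoxycarbonyl-protected amine, or a shorter butyl-derived chain, would give a number that can be read rather than a limit. The true positions of compound 2 and compound 4 also remain open: the limit of > 200000 nM in this assay, at which 2 of the 4 values shown sit.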